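Trifluoromethyl to ethyl on the aryl ether oxygen

The compounds below may be only part of what the source reports. "The series", "measured", "known", "first", "only" and "open" are said of these compounds alone.

Within the data shown here, compound 2 `O=C(O)Cn1nc(Cc2nc3cc(Cl)c(OC(F)(F)F)cc3[nH]2)c2ccccc2c1=O` has the higher of the two numbers measured so far: in a functional assay on CHO cells for antagonist activity at sphingosine 1-phosphate receptor 2 (Homo sapiens), read by GTPgammaS binding (a higher number here means a weaker inhibitor, a lower number a stronger inhibitor), compound 2 gives 342 nM. Compound 1 `CCOc1cc2[nH]c(Cc3nn(CC(=O)N4CCOCC4)c(=O)c4ccccc34)nc2cc1Cl` gives 22 nM in this assay, a gap beyond the scatter, yet compound 1 and compound 2 differ in more than one place, so no single change can be read from them. Compound 3 `CCOc1cc2[nH]c(Cc3nn(CC(=O)O)c(=O)c4ccccc34)nc2cc1Cl` is compound 2 with ethyl in place of trifluoromethyl on an oxygen on an aromatic ring. Among the measured compounds shown here, no measured pair shows this change on its own. The step is expected to be a 2.3-fold lower number from compound 2 to compound 3 (0.36 log units; beyond the scatter), toward a stronger inhibitor. For compound 3 the estimate in this assay is 150 nM, within 50 nM to 500 nM.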

Compound 3, half-maximal inhibitory concentration: 109 nM
Compound 3: middle estimate off by 1.4-fold (0.14 log units), on the high side; low and high end bracket the measured number.
By their numbers in this assay, from the lowest: compound 1; then compound 3; then compound 2.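

In this assay, ethyl in place of trifluoromethyl on the oxygen gives a 3.1-fold lower number from compound 2 to compound 3 (0.50 log units; beyond the scatter), so this position affects the number while the rest of the molecule stays fixed. Hydroxy in place of morpholin-4-yl on the carbonyl carbon gives a 5.0-fold higher number from compound 1 to compound 3 (0.70 log units; beyond the scatter), so the gap between the two earlier compounds now separates into two single changes, each beyond the scatter. Nothing available explains either step. Still open, going by these compounds, is whether a longer chain such as propyl on that oxygen would give a lower number than ethyl. On these data alone, it is also open whether a different amine, such as piperidine, could replace morpholin-4-yl on the carbonyl carbon.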